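Swapping Methoxy for Fluoro on the Benzyl Group

The source may hold more compounds than are shown below. What is called first, only, known or untested is meant among the compounds shown, and "the series" means these compounds.

Measured so far:
Compound 1 `CCCCCCCC/N=c1\nc(N)c2ncn(Cc3ccccc3)c2c(N)n1` gives 3830 nM in a functional assay on A549 cells (Homo sapiens) for antiproliferative activity, read by WST assay, with a stated time of 72 h; on this read-out higher numbers stand for weaker inhibition and lower numbers for stronger inhibition.
Compound 2 `CCCCCCCC/N=c1\nc(N)c2ncn(Cc3ccc(OC)cc3)c2c(N)n1` gives 5700 nM in this assay.

Compound 2 carries the higher of the two numbers, but it stands close to compound 1: the step of a 1.5-fold higher number from compound 1 to compound 2 (0.17 log units; within the scatter) lies within the scatter of repeated measurements, so the two compounds cannot be told apart on these data. Compound 3 `CCCCCCCC/N=c1\nc(N)c2ncn(Cc3ccc(F)cc3)c2c(N)n1` has not yet been measured in this assay. It differs from compound 2 by a single change: fluoro in place of methoxy on an aromatic carbon. Going by the values given here, the only measured step, the one from compound 1 to compound 2, concerns a different exchange at the same position and was itself within the scatter; no measured step trades a methoxy for a fluoro. No shift beyond the scatter is therefore expected. The estimate for compound 3 in this assay is 4500 nM, with a range from 2000 nM to 11000 nM, which means an expected step of a 1.3-fold lower number from compound 2 to compound 3 (0.10 log units; within the scatter).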

Compound 3, half-maximal inhibitory concentration: 5900 nM
For compound 3 the middle estimate is 1.3-fold (0.12 log units) below the measured one; the range from low to high includes it.
By their numbers in this assay, from the lowest: compounds 1, 2 and 3 (each within the scatter of the next).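

In this assay, the exchange of methoxy for fluoro gives a 1.0-fold higher number from compound 2 to compound 3 (0.01 log units; within the scatter), so these two compounds cannot be told apart. Fluoro in place of hydrogen gives a 1.5-fold higher number from compound 1 to compound 3 (0.19 log units; within the scatter), so this step is also within the scatter, and hydrogen, methoxy and fluoro on this aromatic carbon give numbers that cannot be separated across these three compounds. No information is available that could explain this result.

On these data alone, it remains open whether an amine or a carboxylic acid on the same carbon would give a number beyond the scatter. As far as these compounds go, it is also open whether a shorter or longer chain on the shared core would shift the number more than these exchanges on the benzyl group do.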